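Ortho-hydroxyphenyl hydrazones against gastric cancer cells

This account rests on a few compounds, and the source may have more. Where it says the series, first, only, none or still open, it means among the compounds named here.

Measured so far:
compound 1 `C/C(=N\NC(=O)c1cccc(S(=O)(=O)N2CCOCC2)c1)c1ccc(F)cc1` — > 100000 nM
compound 2 `C/C(=N\NC(=O)c1cccc(S(=O)(=O)N2CCOCC2)c1)c1ccccc1O` — 1220 nM
compound 3 `O=C(N/N=C/c1ccccn1)c1cccc(S(=O)(=O)N2CCOCC2)c1` — 81700 nM

Three compounds share one core and were tested in a functional assay on MGC-803 cells (Homo sapiens) for antiproliferative activity, read by MTT assay, with a stated time of 72 h; a lower number here means a stronger inhibitor, a higher number a weaker inhibitor. Compound 1 gives only a limit of the assay, > 100000 nM. Compound 2 gives 1220 nM, and compound 3 gives 81700 nM. Among the compounds with values here, compound 3 thus stands highest of the two numbers, and the only neighbour with a number is compound 2, a large gap below it.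

Within the data shown here, the one measured step is an at least 81-fold lower number from compound 1 to compound 2 (1.91 log units; beyond the scatter), which shows that a 2-hydroxyphenyl group on the carbon doubly bonded to nitrogen brings a far lower number than 4-fluorophenyl.

Compound 4 `CCOc1cccc(/C=N/NC(=O)c2cccc(S(=O)(=O)N3CCOCC3)c2)c1O` is not yet measured. It differs from compound 3 by 3-ethoxy-2-hydroxyphenyl in place of pyridin-2-yl on a carbon with a double bond to nitrogen. The entering group carries the same hydroxyl arrangement as compound 2, so the step from compound 1 to compound 2 bears on it directly. A large drop in this assay is therefore expected, a 41-fold lower number from compound 3 to compound 4 (1.61 log units; beyond the scatter), landing near compound 2. Compound 4 is estimated at 2000 nM, within 500 nM to 10000 nM.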

Compound 4, half-maximal inhibitory concentration: 18000 nM
Beside the measured number, compound 4's estimate is 9.0-fold (0.95 log units) below it; the measured number lies above the stated range.
By their numbers in this assay, from the lowest: compound 2; then compound 4; then compound 3. At a limit, above all of these: compound 1.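

On a carbon with a double bond to nitrogen, 3-ethoxy-2-hydroxyphenyl in place of pyridin-2-yl brings, in this assay, a 4.5-fold lower number from compound 3 to compound 4 (0.66 log units; beyond the scatter) and so a real but modest gain. A hydroxyl-bearing ring at this place now lowers the number against a second group, pyridin-2-yl, and not only against 4-fluorophenyl. Within the data shown here, compound 1 is only a limit of the assay, so this new step is the first at this place with a definite size: the limit of > 100000 nM in this assay, at which 1 of the 4 values shown sits.

As far as these compounds go, the change swaps the ring and adds the ethoxy chain in one move, so the share of each in the gain stays unknown. From the compounds shown here alone, whether a methoxy or propoxy chain in place of ethoxy, or an amine in place of the hydroxyl, would keep or enlarge the gain also remains open.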